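The source may hold more compounds than are shown below. What is called first, only, known or untested is meant among the compounds shown, and "the series" means these compounds.

Working notes on the series. Going by the values given here, compound 2 `O=C(COc1ccc2cc(/C=C3/SC(=O)NC3=O)ccc2c1)Nc1ccc(F)cc1F` is the first reference point. In an assay on isolated protein for inhibition of histone deacetylase 8 (Homo sapiens), with a stated time of 1 h (on this read-out lower numbers stand for stronger inhibition and higher numbers for weaker inhibition), compound 2 gives only a limit, > 50000 nM. Compound 1 `O=C(COc1ccc2cc(/C=C3/SC(=O)NC3=O)ccc2c1)Nc1ccc(Br)cc1F` also gives only a limit in this assay, > 50000 nM. Among the compounds with values here, the one measured step, a step that the two limits leave unreadable from compound 1 to compound 2, cannot be read, since (the limit of > 50000 nM in this assay, at which 2 of the 2 values shown sit). Compound 3 `O=C(COc1ccc2cc(/C=C3/SC(=O)NC3=O)ccc2c1)Nc1ccc([N+](=O)[O-])cc1` differs from compound 2 by 4-nitrophenyl in place of 2,4-difluorophenyl on an amide-type nitrogen. Within the data shown here, no measured step gives a size for this change, as both reference values sit at the limit. Compound 3 is therefore expected to stay near that limit. For compound 3 the expected step is a step that the limit leaves unreadable from compound 2 to compound 3. The estimate for compound 3 is 70000 nM, between 15000 nM and 300000 nM.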

Compound 3, half-maximal inhibitory concentration: 4000 nM
For compound 3 the middle estimate is 18-fold (1.24 log units) above the measured one; the whole stated range lies above it.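

In this assay, the change on this amide-type nitrogen gives an at least 12-fold lower number from compound 2 to compound 3 (1.09 log units; beyond the scatter), and the 4-bromo-2-fluorophenyl counterpart gives an at least 12-fold lower number from compound 1 to compound 3 (1.09 log units; beyond the scatter). With the shared core unchanged, this position can therefore move the read-out clear of the limit, so the group on this nitrogen now has a readable effect. Compound 1 and compound 2 remain unreadable against each other: the limit of > 50000 nM in this assay, at which 2 of the 3 values shown sit.

The compounds shown do not separate the entry of the nitro group from the loss of the halogens. From the compounds shown here alone, how an amine or a carboxylic acid in place of the nitro group would read stays open.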